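The source may hold more compounds than are shown below. What is called first, only, known or untested is meant among the compounds shown, and "the series" means these compounds.

Measured so far: compound 1 `Cc1nnc(SCc2cc(=O)c3ccccc3o2)o1` gives > 25000 nM in a functional assay on MDA-MB-435S cells (Homo sapiens) for cytotoxicity, read by MTT assay, with a stated time of 72 h; a higher number here means a weaker inhibitor, a lower number a stronger inhibitor; compound 2 `Cc1ccc2oc(CSc3nnc(N)s3)cc(=O)c2c1` gives > 25000 nM.

In this assay compound 2 stands at a limit, > 25000 nM, not a measured number. Every value seen so far sits at the limit of > 25000 nM in this assay, at which 2 of the 2 values shown sit. Compound 3 `Cc1ccc2oc(CSc3nnc(C)o3)cc(=O)c2c1` differs from compound 2 by 5-methyl-1,3,4-oxadiazol-2-yl in place of 5-amino-1,3,4-thiadiazol-2-yl on a sulfur. Among the compounds with values here, no step between measured compounds is available, so the size of this change cannot be read from data; compound 1, which carries the same 5-methyl-1,3,4-oxadiazol-2-yl on a sulfur, gives > 25000 nM, itself a limit. Compound 3 is therefore expected to remain at the limit, estimated at 40000 nM (20000 nM to 120000 nM). The expected step that the limit leaves unreadable from compound 2 to compound 3 is none beyond the scatter.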

Compound 3, half-maximal inhibitory concentration: > 25000 nM
Compound 3: no number, only a limit; the forecaster's own chance of this, stated with the estimate: 85%; the middle value lies beyond the limit too.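

Compound 3 gives > 25000 nM in this assay, which is a limit, so its steps from compound 1 and compound 2 cannot be read. The compounds shown leave open which group on the sulfur, if any, would give a measured value: the limit of > 25000 nM in this assay, at which 3 of the 3 values shown sit.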